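Nitro for Trifluoromethyl on a Diaryl Urea Series

A few compounds are considered here, and "the series" means these few. Any claim that something is new, unique, unknown or untested is made for them only; others in the source may bear on it.

Measured so far:
compound 1, `O=C(NCCCCC(c1ccc(F)cc1)c1ccc(F)cc1)Nc1ccc(Cl)cc1`: 82%
compound 2, `Cc1cc(Cl)ccc1NC(=O)NCCCCC(c1ccc(F)cc1)c1ccc(F)cc1`: 58%
compound 3, `COc1ccc(C(CCCCNC(=O)Nc2ccc(Cl)c(C(F)(F)F)c2)c2ccc(OC)cc2)cc1`: 75%

All three compounds were tested in an ADME assay on isolated protein for inhibition of sodium-dependent dopamine transporter (Homo sapiens), tested at 10 uM; a higher number here means more inhibition at the concentration tested (going by the name of the read-out), a lower number less inhibition. Among the three numbers compound 3 stands second highest; the nearest is compound 1, whose number is higher but within the scatter, and the furthest is compound 2, whose number is lower by more than the scatter. Among the measured compounds shown here, the one measured step between close pairs, a number 24 percentage points lower from compound 1 to compound 2 (beyond the scatter), concerns a methyl in place of hydrogen and so does not touch the change considered here.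

Compound 4, `COc1ccc(C(CCCCNC(=O)Nc2ccc(Cl)c([N+](=O)[O-])c2)c2ccc(OC)cc2)cc1`, differs from compound 3 in one place: nitro in place of trifluoromethyl on an aromatic carbon. For the measured compounds named here, no measured pair shows the effect of a nitro replacing a trifluoromethyl on this aromatic carbon, so the expectation rests on compound 3 alone, with added uncertainty. Compound 4 is expected to stay near compound 3, with a step of a number 5 percentage points lower from compound 3 to compound 4 (within the scatter), which is no change beyond the scatter. The estimate for compound 4 in this assay is 70%, expected within 50% to 88%.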

Compound 4, a percentage reported as inhibition, at one concentration (the size of the read-out at that concentration, not a potency): 64%
Compound 4: middle estimate off by 6 percentage points, on the high side; the measured number falls inside the stated range.
By their numbers in this assay, from the lowest: compounds 2 and 4 (each within the scatter of the next); then compounds 3 and 1 (each within the scatter of the next).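

In this assay, among the compounds shown here, nitro in place of trifluoromethyl on this aromatic carbon, ortho to a chloro group, gives a number 11 percentage points lower from compound 3 to compound 4 (beyond the scatter) and is the first measured change at this position. The group held here therefore matters to the read-out, although the step is modest and compound 4 still shows clear inhibition at 64% in this single-concentration test. No measurement at hand explains why the nitro compound reads lower.

The compounds shown leave open whether the same swap would give a similar step on the core of compound 1, since this change rests on one pair alone. They also leave open how a nitrile, an amine or a carboxylic acid on this same carbon would compare with trifluoromethyl and nitro.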